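A few compounds are considered here, and "the series" means these few. Any claim that something is new, unique, unknown or untested is made for them only; others in the source may bear on it.

Compound 2 `COc1cc(N(Cc2nc3ccccc3[nH]2)S(=O)(=O)c2ccccc2Cl)cc(OC)c1OC` gives 34500 nM in a functional assay on PC-3 cells (Homo sapiens) for inhibition, read by MTT assay, with a stated time of 48 h (a higher number here means a weaker inhibitor, a lower number a stronger inhibitor), the highest of the two numbers measured. Among the measured compounds shown here, compound 1 `COc1cc(N(Cc2nc3ccccc3[nH]2)S(=O)(=O)c2ccc(F)cc2)cc(OC)c1OC` gives 7990 nM in this assay, and the step of a 4.3-fold higher number from compound 1 to compound 2 (0.64 log units; beyond the scatter) is the only measured step. Compound 3 `COc1cc(N(Cc2nc3ccccc3[nH]2)S(=O)(=O)c2ccc(C(C)(C)C)cc2)cc(OC)c1OC` differs from compound 2 by 4-(tert-butyl)phenyl in place of 2-chlorophenyl on a sulfonyl sulfur. The measured step bears on this change. Both steps exchange the group on the sulfonyl sulfur. The group that leaves is the one that gave the higher number, so a partial return toward the number of compound 1 is expected, with a step of a 2.9-fold lower number from compound 2 to compound 3 (0.46 log units; beyond the scatter) in this assay. Compound 3 is therefore expected at 12000 nM, within a range from 4000 nM to 40000 nM.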

Compound 3, half-maximal inhibitory concentration: 29800 nM
The estimate for compound 3 lay 2.5-fold (0.40 log units) below the measured number; low and high end bracket the measured number.
By their numbers in this assay, from the lowest: compound 1; then compounds 3 and 2 (each within the scatter of the next).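

In this assay the change on a sulfonyl sulfur gives a 1.2-fold lower number from compound 2 to compound 3 (0.06 log units; within the scatter) and so leaves 4-(tert-butyl)phenyl and 2-chlorophenyl within the scatter of each other. Tert-butyl in place of fluoro on an aromatic carbon gives a 3.7-fold higher number from compound 1 to compound 3 (0.57 log units; beyond the scatter) and so, of these three compounds, compound 1 alone stands apart, as the strongest inhibitor. Nothing measured here explains why the 4-fluorophenyl group stands apart. From the compounds shown here alone, whether an amine or a carboxylic acid in place of the fluoro would give a number lower than that of compound 1 stays open.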